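The source may hold more compounds than are shown below. What is called first, only, known or untested is meant among the compounds shown, and "the series" means these compounds.

The measured compounds:
Compound 1, `O=C(COc1ccc(C(=O)/C=C/c2cccc(Br)c2)cc1)N[C@H]1CCOC1=O`, gives 7890 nM in a functional assay on PC-3 cells (Homo sapiens) for antiproliferative activity, read by MTT assay, with a stated time of 72 h; on this read-out higher numbers stand for weaker inhibition and lower numbers for stronger inhibition.
Compound 2, `CC(C)c1ccc(NCC(=O)N[C@H]2CCOC2=O)cc1`, reaches only the limit > 64000 nM in this assay.
Compound 3, `Cc1ccc(C(C)C)c(OCCSC(=S)N[C@H]2CCOC2=O)c1`, reaches only the limit > 64000 nM in this assay.

Compound 2 thus stands at a limit of this assay rather than at a number, and that is the limit of > 64000 nM in this assay, at which 2 of the 3 values shown sit. Within the data shown here, no step between two measured compounds is available here. Compound 4, `O=C(CNc1ccc(F)cc1)N[C@H]1CCOC1=O`, differs from compound 2 by fluoro in place of isopropyl on an aromatic carbon. With compound 2 sitting at a limit, the measured pairs give no direction to read off, and the change is expected to leave compound 4 near or at that limit, within the scatter. Compound 4 is therefore expected to give about 70000 nM in this assay, between 15000 nM and 300000 nM. This is expected to amount to a step that the limit leaves unreadable from compound 2 to compound 4, no larger than the scatter.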

Compound 4, half-maximal inhibitory concentration: > 64000 nM
Compound 4: only a limit was reported; the forecaster's own chance of this, stated with the estimate: 70%; the middle value is on the limit's open side.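

No step can be read from compound 2 to compound 4, as each stands at a limit rather than at a number: the limit of > 64000 nM in this assay, at which 3 of the 4 values shown sit.

The compounds shown leave open whether fluoro in place of isopropyl on an aromatic carbon changes the result in this assay at all.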